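The source may hold more compounds than are shown below. What is called first, only, known or untested is meant among the compounds shown, and "the series" means these compounds.

Working notes on the hydantoin-free description: the shared core carries a benzyl hydroxamate on one ring nitrogen. In an assay on isolated protein for inhibition of protein deacetylase HDAC6 (Homo sapiens), read by fluorescence, with stated times of 10 min and 2 h (a higher number here means a weaker inhibitor, a lower number a stronger inhibitor), compound 1 `O=C(NO)c1ccc(CN2C(=O)CN(Cc3ccc(Cl)cc3)C2=O)cc1` gives 8.3 nM, compound 2 `CCCC1(c2ccccc2)NC(=O)N(Cc2ccc(C(=O)NO)cc2)C1=O` gives 50.9 nM, and compound 3 `O=C(NO)c1ccc(CN2C(=O)NC(Cc3ccc(Cl)cc3)(c3ccccc3)C2=O)cc1` gives 54 nM. Compound 3 holds the highest of the three numbers; the nearest is compound 2, separated from it only within the scatter, and the furthest is compound 1, which is well apart from it. Going by the values given here, the single measured step at the saturated chain carbon, a 1.1-fold higher number from compound 2 to compound 3 (0.03 log units; within the scatter), left the number where it was.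

Compound 4 `CC(C)(C)c1ccc(CC2(c3ccccc3)NC(=O)N(Cc3ccc(C(=O)NO)cc3)C2=O)cc1` differs from compound 3 by tert-butyl in place of chloro on an aromatic carbon. Among the compounds with values here, no measured step changes a substituent on this aromatic ring, so the only evidence that bears on it is indirect: the step from compound 2 to compound 3 showed that a large change at the same arm did not move the number. On that basis the step expected in this assay is a 1.2-fold higher number from compound 3 to compound 4 (0.08 log units; within the scatter), a change not beyond the scatter. Compound 4 is therefore estimated to give 65 nM, with a range from 25 nM to 170 nM.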

Compound 4, half-maximal inhibitory concentration: 115 nM
Estimate against measurement, compound 4: 1.8-fold (0.25 log units) below, within the range that was stated.
By their numbers in this assay, from the lowest: compound 1; then compounds 2 and 3 (each within the scatter of the next); then compound 4.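

In this assay this arm no longer looks indifferent to change: tert-butyl in place of chloro on the aromatic carbon gives a 2.1-fold higher number from compound 3 to compound 4 (0.33 log units; beyond the scatter) while ethyl to 4-chlorophenyl had given a 1.1-fold higher number from compound 2 to compound 3 (0.03 log units; within the scatter) at the same arm. Read from the ethyl end, 4-(tert-butyl)phenyl gives a 2.3-fold higher number from compound 2 to compound 4 (0.35 log units; beyond the scatter) so a substituted phenyl here is not neutral in every case, and the outcome depends on the group it carries. Nothing measured explains the difference between chloro and tert-butyl at this carbon.

Two groups on this aromatic carbon do not establish a trend, and a methyl, a methoxy group, an amine or a carboxylic acid there would test whether one exists. On these data alone, whether the same exchange on the 4-chlorobenzyl of compound 1 would give a similar step also remains open.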